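Removing the bromoethenyl carbonyl group from compound 1

The source may hold more compounds than are shown below. What is called first, only, known or untested is meant among the compounds shown, and "the series" means these compounds.

Measured in a functional assay on MOLT-4 cells (Homo sapiens) for antiproliferative activity, with a stated time of 48 h; a higher number here means a weaker inhibitor, a lower number a stronger inhibitor:
Compound 1 `C=C(Br)C(=O)Nc1ccc(C(=O)/C=C/c2cccc(OC)c2)cc1`: 1100 nM
Compound 2 `C=C(Br)C(=O)Nc1ccc(C(=O)/C=C/c2cccc(OC)c2OC)cc1`: 490 nM
Compound 3 `C=C(Br)C(=O)Nc1ccc(C(=O)/C=C/c2ccc(OC)c(OC)c2)cc1`: 1800 nM

At 1100 nM, compound 1 sits within a narrow spread of numbers. Its nearest neighbour gives a 1.6-fold higher number from compound 1 to compound 3 (0.21 log units; within the scatter), and its furthest gives a 2.2-fold lower number from compound 1 to compound 2 (0.35 log units; beyond the scatter). Both steps put methoxy in place of hydrogen on an aromatic carbon, and neither touches the nitrogen that changes next.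

Compound 4 `COc1cccc(/C=C/C(=O)c2ccc(N)cc2)c1` differs from compound 1 by hydrogen in place of (1-bromoethenyl)carbonyl on a nitrogen on an aromatic ring. Among the measured compounds shown here, compound 1, compound 2 and compound 3 all carry this group, so no measured step shows what its removal does. The methoxy steps therefore give no direct guide, and the forecast in this assay is a judgement rather than a measured trend. Losing a whole group is expected to outweigh those small steps and to give a higher number, meaning a weaker inhibitor. The expected step is an 11-fold higher number from compound 1 to compound 4 (1.04 log units; beyond the scatter). Compound 4 is estimated at 12000 nM, with an expected range of 3000 nM to 50000 nM.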

Compound 4, half-maximal inhibitory concentration: 21000 nM
Compound 4: middle estimate off by 1.8-fold (0.24 log units), on the low side; low and high end bracket the measured number.
By their numbers in this assay, from the lowest: compound 2; then compounds 1 and 3 (each within the scatter of the next); then compound 4.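

Putting hydrogen in place of (1-bromoethenyl)carbonyl on the nitrogen gives a 19-fold higher number from compound 1 to compound 4 (1.28 log units; beyond the scatter) in this assay and is a large step, whereas compounds 1, 2 and 3 all carried this group and could show only the effect of methoxy changes. The ((1-bromoethenyl)carbonyl)amino group therefore contributes strongly to the potency of compound 1, although compound 4 with its plain amino group still gives a measured number of 21000 nM in this assay. No evidence here explains the size of this step.

From the compounds shown here alone, what remains open is which part of the departing group matters: the bromine, the double bond or the carbonyl, a question that an acetyl or acryloyl group on the same nitrogen would help to answer. Also open, going by these compounds, is whether removing the group costs as much when the methoxy groups of compound 2 or compound 3 are present.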